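This account rests on a few compounds, and the source may have more. Where it says the series, first, only, none or still open, it means among the compounds named here.

Measured so far, in a functional assay on PC-3 cells (Homo sapiens) for cytotoxicity, read by MTT assay, with a stated time of 72 h; on this read-out higher numbers stand for weaker inhibition and lower numbers for stronger inhibition:
compound 1 `FC(F)(F)c1ccc(CSc2nc(Nc3ccccc3)c3ccccc3n2)cc1` — 20000 nM
compound 2 `FC(F)(F)c1ccc(CSc2nc(Nc3cccc(Br)c3)c3ccccc3n2)cc1` — 8680 nM

Going by the values given here, compound 2 holds the lower of the two numbers in this assay; the only step, a 2.3-fold lower number from compound 1 to compound 2 (0.36 log units; beyond the scatter), set it apart from compound 1. Compound 3 `O=[N+]([O-])c1cccc(Nc2nc(SCc3ccc(C(F)(F)F)cc3)nc3ccccc23)c1` differs from compound 2 by nitro in place of bromo on an aromatic carbon. Among the compounds with values here, no measured pair shows nitro against bromo, so the step from compound 1 to compound 2 bears on it only as a sign that a group on this ring can move the number modestly. The step is therefore expected to be small, a 1.2-fold lower number from compound 2 to compound 3 (0.09 log units; within the scatter). Compound 3 is estimated at 7000 nM, in the range 2500 nM to 20000 nM.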

Compound 3, half-maximal inhibitory concentration: 13500 nM
Estimate against measurement, compound 3: 1.9-fold (0.29 log units) below; the measured number falls inside the stated range.
By their numbers in this assay, from the lowest: compounds 2, 3 and 1 (each within the scatter of the next, the first and the last beyond it).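

In this assay, nitro and bromo on this aromatic carbon cannot be told apart (a 1.6-fold higher number from compound 2 to compound 3 (0.19 log units; within the scatter)). Nitro also cannot be told apart from the hydrogen of the parent (a 1.5-fold lower number from compound 1 to compound 3 (0.17 log units; within the scatter)), so of the two groups only bromo has a step from hydrogen printed as beyond the scatter (a 2.3-fold lower number from compound 1 to compound 2 (0.36 log units; beyond the scatter)). Nothing available explains this result. The compounds shown leave open whether an amine, a carboxylic acid or a methoxy group here would move the number further. They also leave open whether bromo elsewhere on this ring would give a similar step.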